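A few compounds are considered here, and "the series" means these few. Any claim that something is new, unique, unknown or untested is made for them only; others in the source may bear on it.

Compound 3 `Fc1ccc(-c2cn3ccnc3c(-c3ccc4ncn(C5CCCCC5)c4c3)n2)cc1` stands second highest of the three numbers available in a functional assay on UACC-62 cells (Homo sapiens) for inhibition, read by sulforhodamine B assay, with a stated time of 48 h, tested at 10 uM; a higher number here means more inhibition at the concentration tested (going by the name of the read-out), a lower number less inhibition. In this assay compound 3 gives 31%. Compound 2 `c1ccc(-c2cn3ccnc3c(-c3ccc4ncn(C5CCCCC5)c4c3)n2)cc1` gives 65.7% and compound 1 `Brc1cn2ccnc2c(-c2ccc3ncn(C4CCCCC4)c3c2)n1` gives 19.8%. Compound 4 `CC(=O)c1ccc(-c2cn3ccnc3c(-c3ccc4ncn(C5CCCCC5)c4c3)n2)cc1` differs from compound 3 by acetyl in place of fluoro on an aromatic carbon, a change on the aromatic carbon that sits para to a large group. Among the compounds with values here, no measured step exchanges fluoro for acetyl, so the nearest guide is the step of a number 34.7 percentage points lower from compound 2 to compound 3 (beyond the scatter), which shows that what sits on this ring moves the read-out a long way. The steps of a number 45.9 percentage points higher from compound 1 to compound 2 (beyond the scatter) and a number 11.2 percentage points higher from compound 1 to compound 3 (beyond the scatter) show that the kind of aryl group set in place of bromo on the shared core also shifts the number by a large or a modest amount. Taken together, these steps leave the direction of the acetyl change open: the ring bearing hydrogen gave the highest number and the ring bearing fluoro a lower one, so acetyl could land on either side of compound 3. Compound 4 is therefore expected to give a result near the middle of the measured spread, with a step of a number 9 percentage points higher from compound 3 to compound 4 (within the scatter) that may well stay within the scatter. The estimate for compound 4 is 40%, with a range from 15% to 68%.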

Compound 4, a percentage reported as inhibition, at one concentration (the size of the read-out at that concentration, not a potency): 18.5%
Estimate against measurement, compound 4: 21.5 percentage points above; the range from low to high includes it.
By their numbers in this assay, from the lowest: compounds 4 and 1 (each within the scatter of the next); then compound 3; then compound 2.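

In this assay, the exchange of fluoro for acetyl on the aromatic carbon para to a large group settles the direction that was still open (a number 12.5 percentage points lower from compound 3 to compound 4 (beyond the scatter)), and the comparison with the unsubstituted ring (a number 47.2 percentage points lower from compound 2 to compound 4 (beyond the scatter)) places both substituents shown at this position lower than hydrogen, with acetyl the lower of the two. The step from bromo to 4-acetylphenyl on the shared core (a number 1.3 percentage points lower from compound 1 to compound 4 (within the scatter)) shows that the large rise found with plain phenyl (a number 45.9 percentage points higher from compound 1 to compound 2 (beyond the scatter)) does not carry over to every aryl group, so the gain depends on what this ring bears at that position. Nothing available explains why acetyl and fluoro lower the number at this position.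

The compounds shown leave open whether any group on this carbon can match or pass hydrogen in this assay, for instance methyl, methoxy, an amine or a carboxylic acid. With only hydrogen, fluoro and acetyl at this position, they also leave open whether the order among these three would extend to other groups, and a reading at one concentration gives no potency for any of them.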